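Replacing the cyclohexyl-bearing group of compound 2

The source may hold more compounds than are shown below. What is called first, only, known or untested is meant among the compounds shown, and "the series" means these compounds.

In an ADME assay on HepG2 2.2.15 cells (Homo sapiens) for cytotoxicity (on this read-out higher numbers stand for lower toxicity in this test and lower numbers for higher toxicity in this test), compound 1 `COCC(=O)OCCc1c(-c2ccccc2Cl)c2cc(Cl)ccc2[nH]c1=O` gives 74000 nM and compound 2 `O=C(CCC1CCCCC1)OCCc1c(-c2ccccc2Cl)c2cc(Cl)ccc2[nH]c1=O` gives 160000 nM, the higher of the two numbers. Compound 3 `O=C(OCCc1c(-c2ccccc2Cl)c2cc(Cl)ccc2[nH]c1=O)c1ccco1` carries furan-2-yl in place of 2-cyclohexylethyl on a carbonyl carbon. Within the data shown here, only one measured step bears on this change: a 2.2-fold higher number from compound 1 to compound 2 (0.33 log units; beyond the scatter), a modest move that also altered the group on this carbonyl. One step is thin evidence, so only a modest fall back towards compound 1 is expected. The expected step is a 1.7-fold lower number from compound 2 to compound 3 (0.23 log units; within the scatter). Compound 3 is estimated at 95000 nM, with an expected range of 40000 nM to 220000 nM.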

Compound 3, half-maximal cytotoxic concentration: 98000 nM
The estimate for compound 3 lay 1.0-fold (0.01 log units) below the measured number; measured number inside the range.
By their numbers in this assay, from the lowest: compounds 1, 3 and 2 (each within the scatter of the next, the first and the last beyond it).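

In this assay the change reads a 1.6-fold lower number from compound 2 to compound 3 (0.21 log units; within the scatter) and, set against the methoxymethyl group, a 1.3-fold higher number from compound 1 to compound 3 (0.12 log units; within the scatter) on the same carbonyl carbon. So this position accepts an aromatic furan-2-yl ring as well as the saturated groups, and compound 3 cannot be told apart from either neighbour. Nothing measured here explains these numbers. Going by these compounds, whether a phenyl ring or a chain ending in an amine or a carboxylic acid on this carbonyl would give a number beyond the scatter stays open.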